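A Third Aryl Variant Against a Breast Cancer Cell Line

This account rests on a few compounds, and the source may have more. Where it says the series, first, only, none or still open, it means among the compounds named here.

In a functional assay on MDA-MB-468 cells (Homo sapiens) for antiproliferative activity, read by MTT assay, with a stated time of 24 h (on this read-out lower numbers stand for stronger inhibition and higher numbers for weaker inhibition), compound 1 `CNC(=O)c1ccccc1Oc1nc(Nc2ccccc2OC)ncc1Br` reaches only the assay limit, > 50000 nM. Compound 2 `CNC(=O)c1ccccc1Oc1nc(Nc2ccc(Cl)cc2F)ncc1Br` likewise gives only the limit > 50000 nM in this assay. Among the measured compounds shown here, the single measured step, a step that the two limits leave unreadable from compound 1 to compound 2, therefore cannot be sized, since both values sit at the same limit (the limit of > 50000 nM in this assay, at which 2 of the 2 values shown sit). Compound 3 `CNC(=O)c1ccccc1Oc1nc(Nc2cccc(C(C)C)c2)ncc1Br` differs from compound 2 by 3-isopropylphenyl in place of 4-chloro-2-fluorophenyl on a nitrogen on an aromatic ring. With no readable step to lean on, compound 3 is expected to remain at the limit as well, an estimated a number no higher from compound 2 to compound 3 (the limit leaves the size open). The estimate for compound 3 is 50000 nM, within 10000 nM to 100000 nM.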

Compound 3, half-maximal inhibitory concentration: 19500 nM
Compound 3: middle estimate off by 2.6-fold (0.41 log units), on the high side; the range from low to high includes it.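

In this assay, among the compounds shown here, compound 3 is the only one of the three compounds with a measured number rather than a limit, so changing the aryl group on this nitrogen can move the read-out. Placing 3-isopropylphenyl here gives an at least 2.5-fold lower number from compound 2 to compound 3 (0.40 log units; beyond the scatter), and likewise an at least 2.5-fold lower number from compound 1 to compound 3 (0.40 log units; beyond the scatter). Both sizes are minimums, since the true values of the other two compounds lie beyond a limit: the limit of > 50000 nM in this assay, at which 2 of the 3 values shown sit.

As far as these compounds go, whether a longer chain in place of the isopropyl group would lower the number further remains open. So does the effect of an amine or a carboxylic acid on this phenyl ring.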